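A Third Aryl Group on the Ring Nitrogen

The compounds below may be only part of what the source reports. "The series", "measured", "known", "first", "only" and "open" are said of these compounds alone.

Of the compounds shown here, two have so far been tested in an assay on HEK293 cells for inhibition of Voltage-dependent T-type calcium channel subunit alpha-1G (Homo sapiens), read by patch clamp; on this read-out lower numbers stand for stronger inhibition and higher numbers for weaker inhibition. Compound 1 `O=C(CCCN1CCN(c2ccccc2F)CC1)Nc1ccc(Cl)cc1` gives 3630 nM, and compound 2 `O=C(CCCN1CCN(c2ccc(Cl)cc2)CC1)Nc1ccc(Cl)cc1` gives 2640 nM. Among the compounds with values here, the only step between them, a 1.4-fold lower number from compound 1 to compound 2 (0.14 log units; within the scatter), is too small to read as a real difference, so compound 2 stands side by side with compound 1 rather than apart from it.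

Compound 3 `COc1ccccc1N1CCN(CCCC(=O)Nc2ccc(Cl)cc2)CC1` has not been measured. It differs from compound 2 in one place: 2-methoxyphenyl in place of 4-chlorophenyl on an amine nitrogen in a ring. Within the data shown here, the one step that bears on this change is a 1.4-fold lower number from compound 1 to compound 2 (0.14 log units; within the scatter), which stayed within the scatter when one aryl group replaced another at the same ring nitrogen. On that basis the new aryl group is expected to leave this assay essentially unchanged, with a 1.1-fold higher number from compound 2 to compound 3 (0.03 log units; within the scatter) as the estimated step. Compound 3 is therefore estimated at 2800 nM, within a range from 900 nM to 8000 nM.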

Compound 3, half-maximal inhibitory concentration: 2610 nM
For compound 3 the middle estimate is 1.1-fold (0.03 log units) above the measured one; low and high end bracket the measured number.
By their numbers in this assay, from the lowest: compounds 3, 2 and 1 (each within the scatter of the next).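

With a third aryl group, the ring nitrogen still shows no readable preference in this assay: 2-methoxyphenyl in place of 4-chlorophenyl gives a 1.0-fold lower number from compound 2 to compound 3 (0.00 log units; within the scatter), and methoxy in place of fluoro on the aromatic carbon gives a 1.4-fold lower number from compound 1 to compound 3 (0.14 log units; within the scatter). The step from 4-chlorophenyl also adds one hydrogen-bond acceptor and swaps chlorine for oxygen, yet the two numbers stay within the scatter, so this change has no readable effect here. No measurement is available that would explain this flat result.

All three groups are substituted phenyl rings, so the compounds shown leave open whether a pyridine ring, a benzyl group or a simple methyl on this nitrogen would behave the same way. They also leave open what a longer chain in the shared core would do.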